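Cytotoxicity notes on compound 3 and the methoxy analogue

The source may hold more compounds than are shown below. What is called first, only, known or untested is meant among the compounds shown, and "the series" means these compounds.

Compound 3 `CCOC(=O)CCCCCOc1cccc(CN(C(=O)c2ccc(-c3cccc(C(C)=O)c3)cc2)C(C)C)c1` has been run in an ADME assay on HEK293 cells (Homo sapiens) for cytotoxicity, read by CellTiter-Glo and resazurin assay, with a stated time of 72 h (on this read-out higher numbers stand for an effect only at larger amounts of compound and lower numbers for an effect already at smaller amounts), and returns only a limit of the assay, not a number: compound 3 gives > 26000 nM. Compound 1 `CCOC(=O)CCCCCOc1cccc(CN(C(=O)c2ccc(-c3cccc(N(C)C)c3)cc2)C(C)C)c1` likewise gives a limit in this assay, > 26000 nM. Compound 2 `CCOC(=O)CCCCCOc1cccc(CN(C(=O)c2ccc(-c3cccc(-c4ccccc4)c3)cc2)C(C)C)c1` also returns a limit, > 26000 nM. All three values sit at the limit of > 26000 nM in this assay, at which 3 of the 3 values shown sit, so none of the steps among them can be read in size: a step that the two limits leave unreadable from compound 1 to compound 2, a step that the two limits leave unreadable from compound 1 to compound 3, and a step that the two limits leave unreadable from compound 2 to compound 3 are each unreadable due to the limit of > 26000 nM in this assay, at which 3 of the 3 values shown sit.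

Compound 4 `CCOC(=O)CCCCCOc1cccc(CN(C(=O)c2ccc(-c3cccc(OC)c3)cc2)C(C)C)c1` is not yet measured. It differs from compound 3 in one place: methoxy in place of acetyl on an aromatic carbon. Going by the values given here, no measured step bears on this change with a readable size, and where compound 3 stands is known only as a limit. What is known is that dimethylamino, phenyl and acetyl at this position have each left the read-out at the limit; on that basis a methoxy group is expected to do the same, and the step that the limit leaves unreadable from compound 3 to compound 4 is expected to show no effect readable beyond the scatter, most probably another limit. Compound 4 is estimated in this assay at 40000 nM, within a range of 15000 nM to 100000 nM.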

Compound 4, half-maximal effective concentration: > 21000 nM
Compound 4: no number, only a limit; the forecaster's own chance of this, stated with the estimate: 85%; the middle value does not contradict the limit.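

In this assay compound 4 gives > 21000 nM, a limit and not a number, so the steps to compound 4 from compound 1, compound 2 and compound 3 cannot be read in size: the limit of > 21000 nM in this assay, at which 1 of the 4 values shown sits.

The compounds shown leave open whether dimethylamino, phenyl, acetyl and methoxy differ at all on this read-out.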